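The source may report more compounds than this note shows. Statements on the series, on what has been measured and on what is new or still open speak of the compounds shown alone.

Three compounds sharing one core were examined in an ADME assay on THP-1 cells (Homo sapiens) for cytotoxicity, read by WST assay, with a stated time of 24 h; on this read-out lower numbers stand for stronger inhibition and higher numbers for weaker inhibition. Compound 1 `O=C(Nc1ccccc1C(F)(F)F)c1ccc2cccc(O)c2n1` carries a trifluoromethyl group on its outer ring. In this assay compound 1 gives > 30000 nM, which is a limit of the assay rather than a number. Compound 2 `O=C(Nc1ccc(C(F)(F)F)cc1)c1ccc2cccc(O)c2n1` is built from the same atoms joined differently; how the two cores differ is not broken down here. In this assay compound 2 gives > 30000 nM, again a limit of the assay. Compound 3 `O=C(Nc1ccccc1[N+](=O)[O-])c1ccc2cccc(O)c2n1` differs from compound 1 by nitro in place of trifluoromethyl on an aromatic carbon. In this assay compound 3 gives > 30000 nM, once more a limit. The step that the two limits leave unreadable from compound 1 to compound 3 can therefore not be sized, since both of its ends sit at the limit of > 30000 nM in this assay, at which 3 of the 3 values shown sit.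

Compound 4 `O=C(Nc1ccc([N+](=O)[O-])cc1)c1ccc2cccc(O)c2n1` has not yet been measured. It differs from compound 2 by nitro in place of trifluoromethyl on an aromatic carbon. This is the same kind of change as that from compound 1 to compound 3, but not the same change: in compound 3 the nitro group sits ortho to a large group, whereas in compound 4 it sits para to a large group. The step from compound 2 to compound 4 is expected to be a step that the limit leaves unreadable from compound 2 to compound 4, an expectation that rests on the unreadable step that the two limits leave unreadable from compound 1 to compound 3 and on (the limit of > 30000 nM in this assay, at which 3 of the 3 values shown sit). For compound 4 the expected value in this assay is estimated at 45000 nM, between 20000 nM and 120000 nM, most likely reported only as a limit.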

Compound 4, half-maximal inhibitory concentration: > 30000 nM
Compound 4: a limit, no number (the forecaster's own chance of this, stated with the estimate: 85%); the middle value lies beyond the limit too.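

In this assay compound 4 gives > 30000 nM, which is a limit of the assay and not a number. Among these compounds, no step between compound 2 and compound 4 can be read, as both ends are limits, and the values shown all sit together: the limit of > 30000 nM in this assay, at which 4 of the 4 values shown sit. The compounds shown leave open how far each lies beyond that limit, and whether nitro in place of trifluoromethyl changes anything in this assay.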